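Ethoxy for Methyl: Little Change Expected

A few compounds are considered here, and "the series" means these few. Any claim that something is new, unique, unknown or untested is made for them only; others in the source may bear on it.

Measured compounds and their readings in a functional assay on A-375 cells (Homo sapiens) for antiproliferative activity, read by MTT assay, with a stated time of 24 h, tested at 0.41 ug/mL; a lower number here means a weaker effect, a higher number a stronger effect of the compound at the concentration tested:
Compound 1, `Cc1ccc2nc(C(=O)Nc3c(F)cc(-c4cccc(F)c4)cc3F)c(C)c(O)c2c1`, gives 1.35%.
Compound 2, `Cc1c(C(=O)Nc2ccc(-c3ccccc3)cc2)nc2ccccc2c1O`, gives 2.65%.
Compound 3, `Cc1ccc2nc(C(=O)Nc3c(F)cc(-c4cccc(F)c4)cc3F)c(C)c(C(=O)O)c2c1`, gives 1.53%.

Compound 3 stands second highest of the three numbers, yet all three lie close together near the bottom of the scale. Going by the values given here, its nearest neighbour is compound 1, and the only step in which one place alone differs, a number 0.2 percentage points higher from compound 1 to compound 3 (within the scatter), is within the scatter. Compound 2, with a different pattern on the amide side, gives a number only slightly higher than compound 3, also within the scatter. In short, none of the three compounds shows a marked effect in this assay.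

Compound 4, `CCOc1ccc2nc(C(=O)Nc3c(F)cc(-c4cccc(F)c4)cc3F)c(C)c(C(=O)O)c2c1`, is the next compound to be tested. It differs from compound 3 in one place: ethoxy in place of methyl on an aromatic carbon. Among the compounds with values here, no measured step concerns an ethoxy in place of methyl on an aromatic carbon, so the one measured step, which concerns a different position and was within the scatter, gives no direct guide. Within the data shown here, with every number so far low and flat, no step beyond the scatter is expected in this assay; the step of a number 0.5 percentage points higher from compound 3 to compound 4 (within the scatter) is the estimate. Compound 4 is therefore expected to give about 2%, between 0% and 9%.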

Compound 4, a percentage reported as inhibition, at one concentration (the size of the read-out at that concentration, not a potency): 11.2%
Compound 4: middle estimate off by 9.2 percentage points, on the low side, outside the stated range (above it).
By their numbers in this assay, from the lowest: compounds 1, 3, 2 and 4 (each within the scatter of the next).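

At this position, which carries methyl in compound 3, the change to ethoxy in this assay gives a number 9.7 percentage points higher from compound 3 to compound 4 (within the scatter) and so falls just inside the usual scatter of repeated measurements. Going by these compounds alone, this shows that the position can take ethoxy, a larger group that adds an oxygen, without the reading dropping, and the new reading is the first in this set that is not close to the bottom of the scale; it does not show that ethoxy truly adds an effect. No measurement is available that could explain the reading at this position.

On these data alone, it remains open whether repeat measurements would separate compound 4 from compound 3, and whether a shorter methoxy, a longer propoxy chain or an amine at the same position would give a step clearly beyond the scatter. As far as these compounds go, it is also open whether ethoxy would give a similar step on the core of compound 1, which carries hydroxy where compound 3 carries the carboxy group.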